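The compounds below may be only part of what the source reports. "The series", "measured", "known", "first", "only" and "open" are said of these compounds alone.

Compound 1 `OC(CCn1nc2c(Br)c(Br)c(Br)c(Br)c2n1)c1cccc(Br)c1`: 54%
Compound 2 `OC(CCn1nc2c(Br)c(Br)c(Br)c(Br)c2n1)c1cccc(Cl)c1`: 71%

Among the measured compounds shown here, in a functional assay on CCRF-CEM cells (Homo sapiens) for antiproliferative activity, read by MTT assay, with a stated time of 24 h, tested at 50 uM (a higher number here means a weaker effect of the compound at the concentration tested, a lower number a stronger effect), compound 2 stands highest of the two numbers measured; the single step at hand, a number 17 percentage points higher from compound 1 to compound 2 (beyond the scatter), is modest and beyond the scatter. Compound 3 `OC(CCn1nc2c(Br)c(Br)c(Br)c(Br)c2n1)c1ccc(Cl)cc1` is not yet measured. It differs from compound 2 by 4-chlorophenyl in place of 3-chlorophenyl on a saturated chain carbon bound to an oxygen on a saturated carbon and a saturated chain carbon. For the measured compounds named here, no measured step moves a chlorine to another place on the phenyl ring, and the halogen exchange seen between compound 1 and compound 2 does not bear on this change. Hence no step beyond the scatter is expected: no change at the digits printed from compound 2 to compound 3 (within the scatter). For compound 3 the expected value in this assay is 71%, within 50% to 92%.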

Compound 3, a percentage reported as activity, at one concentration (the size of the read-out at that concentration, not a potency): 56%
For compound 3 the middle estimate is 15 percentage points above the measured one; low and high end bracket the measured number.
By their numbers in this assay, from the lowest: compounds 1 and 3 (each within the scatter of the next); then compound 2.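

In this assay, moving the chlorine alone matters: 4-chlorophenyl in place of 3-chlorophenyl gives a number 15 percentage points lower from compound 2 to compound 3 (beyond the scatter) with the same atoms, so the effect at this position depends on where the halogen sits as well as on which halogen it is. Against 3-bromophenyl, 4-chlorophenyl gives a number 2 percentage points higher from compound 1 to compound 3 (within the scatter), so chlorine does not by itself go with the weaker effect, and compound 2 alone stands apart. No measurement at hand accounts for this shift.

Open, from the compounds shown here alone, is whether 4-bromophenyl would follow the chlorine pair. Also open, going by these compounds, is how a methoxy group or an amine on the phenyl ring would read.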